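A few compounds are considered here, and "the series" means these few. Any claim that something is new, unique, unknown or untested is made for them only; others in the source may bear on it.

Measured so far in a functional assay on B16-F10 cells (Mus musculus) for antiproliferative activity, read by CCK-8 assay, with a stated time of 48 h; a lower number here means a stronger inhibitor, a higher number a weaker inhibitor:
- Compound 1 `COc1ccc(/C=C\c2cc(OC)c(OC)c(OC)c2)cc1OCc1ccc(CN2C[C@H](O)C[C@@H]2C(=O)O)cc1` gives > 10000 nM, a limit of the assay
- Compound 2 `COc1ccc(/C=C\c2cc(OC)c(OC)c(OC)c2)cc1OCc1ccc(CO)cc1` gives 6600 nM
- Compound 3 `COc1ccc(/C=C\c2cc(OC)c(OC)c(OC)c2)cc1OCc1ccc(CN2CC(C(=O)O)C2)cc1` gives > 10000 nM, a limit of the assay

Compound 3 has no number in this assay, only the limit > 10000 nM. That limit is shared across the small set, as shown by the limit of > 10000 nM in this assay, at which 2 of the 3 values shown sit.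

Compound 4 `COc1ccc(/C=C\c2cc(OC)c(OC)c(OC)c2)cc1OCc1ccc(CN[C@H](C(=O)O)[C@@H](C)O)cc1` differs from compound 3 by one change, ((1-carboxy-2-hydroxypropyl)amino in place of 3-carboxyazetidin-1-yl on a saturated chain carbon bound to an aromatic carbon). The ring of the 3-carboxyazetidin-1-yl group is lost, and the open (1-carboxy-2-hydroxypropyl)amino group stands on the same saturated chain carbon bound to an aromatic carbon.

Within the data shown here, three measured steps bear on this. The exchange of one carboxy-bearing amine for another gives a step that the two limits leave unreadable from compound 1 to compound 3. Replacing such a group with hydroxy gives an at least 1.5-fold lower number from compound 1 to compound 2 (0.18 log units; that floor lies within the scatter), and the reverse kind of change gives an at least 1.5-fold higher number from compound 2 to compound 3 (0.18 log units; that floor lies within the scatter). None of these shows a step beyond the scatter, so none is expected here, and the estimate is a step that the limit leaves unreadable from compound 3 to compound 4. A further limit is the likely report.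

For compound 4 the expected value is 12000 nM, with an estimated range from 6000 nM to 30000 nM.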

Compound 4, half-maximal inhibitory concentration: 5400 nM
Estimate against measurement, compound 4: 2.2-fold (0.35 log units) above, outside the stated range (below it).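

In this assay, compound 4 alone among the carboxy-bearing amines gives a number, so a group of this kind on a saturated chain carbon bound to an aromatic carbon can be read at all. Exchanging the ring groups for the open (1-carboxy-2-hydroxypropyl)amino group gives an at least 1.8-fold lower number from compound 3 to compound 4 (0.26 log units; that floor lies within the scatter) and an at least 1.8-fold lower number from compound 1 to compound 4 (0.26 log units; that floor lies within the scatter), and these remain floors rather than sizes: the limit of > 10000 nM in this assay, at which 2 of the 4 values shown sit. Among these compounds, exchanging hydroxy for the same group gives a 1.2-fold lower number from compound 2 to compound 4 (0.09 log units; within the scatter), so a carboxy-bearing amine at this place cannot be told apart from the hydroxy, which the earlier compounds could not show.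

As far as these compounds go, it remains open whether the missing ring or the side-chain hydroxy accounts for the readable value. A plain dimethylamino group, or the methyl ester of the same amino acid, would help separate the two.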